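Replacing a Pyrazole with a Pyridine on a Shared Core

This account rests on a few compounds, and the source may have more. Where it says the series, first, only, none or still open, it means among the compounds named here.

Compound 1 `CNC(=O)N1CCCc2ccc(NC(=O)c3ccc(-c4cc[nH]n4)cc3)cc21` stands highest of three compounds in a functional assay on MV4-11 cells (Homo sapiens) for antiproliferative activity, with a stated time of 6 days, tested at 6.25 uM (a lower number here means a weaker effect, a higher number a stronger effect of the compound at the concentration tested), giving 99.1%. Compound 3 `CNC(=O)N1CCCc2ccc(NC(=O)c3ccccc3-c3ccccc3)cc21` gives 60.4%, and compound 2 `CNC(=O)N1CCCc2ccc(NC(=O)c3cccc(-c4ccccc4)c3)cc21` gives 1.39%; both fall clearly short of compound 1.

Compound 4 `CNC(=O)N1CCCc2ccc(NC(=O)c3ccc(-c4cccnc4)cc3)cc21` keeps the shared core and differs from compound 1 in one place: pyridin-3-yl in place of 1H-pyrazol-3-yl on an aromatic carbon. The group still sits para to a large group, as in compound 1. Within the data shown here, no measured pair shows this kind of exchange, so the size of the step is uncertain. Because compound 1 already reaches 99.1%, little room for a rise remains, and a moderate fall in this assay seems more likely than none. The expected step is a number 29.1 percentage points lower from compound 1 to compound 4 (beyond the scatter). Compound 4 is estimated at 70%, within a range of 20% to 98%.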

Compound 4, a percentage reported as inhibition, at one concentration (the size of the read-out at that concentration, not a potency): 92.1%
Compound 4: middle estimate off by 22.1 percentage points, on the low side, within the range that was stated.
By their numbers in this assay, from the lowest: compound 2; then compound 3; then compounds 4 and 1 (each within the scatter of the next).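

In this assay the exchange of 1H-pyrazol-3-yl for pyridin-3-yl gives a number 7 percentage points lower from compound 1 to compound 4 (within the scatter), so at this place, para to a large group, a six-membered ring without a hydrogen-bond donor serves as well as the five-membered ring with one. This read-out comes from one concentration and does not compare potency. Nothing available explains the result. Open, going by these compounds, is whether a group that is not an aromatic ring, such as an amine or a carboxylic acid, would hold the effect at this place.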